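The source may report more compounds than this note shows. Statements on the series, on what has been measured and on what is new or still open speak of the compounds shown alone.

Measured compounds:
Compound 1 `Cc1ccc(CN2CCc3cc(NC(=O)NCc4ccncc4)ccc32)cc1` — "not determined" (no result reported)
Compound 2 `Cc1ccc(C(=O)n2ccc3cc(NC(=O)NCc4ccncc4)ccc32)cc1` — 89%

Compound 1 has no result in an assay on HEK293-A cells for activation of Nicotinamide phosphoribosyltransferase (Homo sapiens), tested at 10 uM (a higher number here means a stronger effect of the compound at the concentration tested, a lower number a weaker effect), so it stands nowhere on the numbers; no figure for it can be placed on the scale. Compound 2, which also carries a (4-methylphenyl)carbonyl group, gives 89% in this assay, and that is the only measured anchor here.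

Compound 3 `Cc1ccc(C(=O)N2CCc3cc(NC(=O)NCc4ccncc4)ccc32)cc1` is the compound to be measured next. Compared with compound 1, the change is (4-methylphenyl)carbonyl in place of 4-methylbenzyl on a nitrogen on an aromatic ring in a ring. Since compound 1 has no value, no step size from compound 1 to compound 3 can be given at all; the direction of the change is open, and what can be said rests on compound 2 alone.

The expectation for compound 3 is that it reaches an activity near that of compound 2, because compound 2 gives 89% with the same (4-methylphenyl)carbonyl group present. Compound 3 is therefore estimated to give 75%, with a range from 40% to 100%.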

Compound 3, a percentage reported as activity, at one concentration (the size of the read-out at that concentration, not a potency): 62%
The estimate for compound 3 lay 13 percentage points above the measured number, and the stated range covers the measured number.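

Within the data shown here, since compound 1 stands at "not determined" (no result reported) in this assay, no step from compound 1 to compound 3 can be read. The compounds shown leave open whether (4-methylphenyl)carbonyl in place of 4-methylbenzyl raises or lowers the activity in this assay. Nothing shown here offers an explanation for the result of compound 3.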